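Methyl in place of hydrogen beside a fused ring

A few compounds are considered here, and "the series" means these few. Any claim that something is new, unique, unknown or untested is made for them only; others in the source may bear on it.

compound 1 `N=C(N)Nc1ccc2nccnc2c1Br`: 17000 nM
compound 2 `c1cc2c(cc1NC1=NCCN1)OCCO2`: 2400 nM

Of the compounds shown here, two have been measured in an assay on Cerebral cortex for binding affinity to Adrenergic receptor alpha-1 (Homo sapiens); a lower number here means a stronger inhibitor, a higher number a weaker inhibitor. Compound 1 gives 17000 nM and compound 2 gives 2400 nM. Compound 2 holds the lower of these two numbers, and compound 1 stands beyond the scatter above it. Compound 3 `Cc1c(NC2=NCCN2)ccc2c1OCCO2` differs from compound 2 by one change: methyl in place of hydrogen on an aromatic carbon. Among the compounds with values here, no measured pair shows a step of this kind, so its size is unknown; a change no larger than the scatter, in either direction, is expected in this assay. Compound 3 is therefore estimated at 1800 nM with a range from 500 nM to 6500 nM, an expected step of a 1.3-fold lower number from compound 2 to compound 3 (0.12 log units; within the scatter).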

Compound 3, inhibition constant: 130 nM
Compound 3: the middle estimate sits 14-fold (1.14 log units) above what was measured; measured number outside the range, below it.
By their numbers in this assay, from the lowest: compound 3; then compound 2; then compound 1.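

In this assay, methyl in place of hydrogen on an aromatic carbon, ortho to a fused ring and ortho to a group of 6 heavy atoms, gives an 18-fold lower number from compound 2 to compound 3 (1.27 log units; beyond the scatter) and so forms a large step. Within the data shown here, it is the first step read between compounds that differ in one place, and it shows that this position responds strongly to a single added carbon. Nothing measured here accounts for the size of the step. As far as these compounds go, whether ethyl, chlorine or methoxy at this position would act like methyl remains open. So does whether methyl would give a similar step on the core of compound 1.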